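The source may report more compounds than this note shows. Statements on the series, on what has been measured and on what is new or still open speak of the compounds shown alone.

Measured compounds:
compound 1, `NC(=O)c1cn(Cc2ccccc2)c2ncnc(N)c12`: 75000 nM
compound 2, `CCCn1cc(C#N)c2c(N)ncnc21`: > 100000 nM

In a functional assay on KB cells (Homo sapiens) for cytotoxicity (a higher number here means a weaker inhibitor, a lower number a stronger inhibitor), compound 1 gives 75000 nM. Compound 2 reaches only > 100000 nM, which is a limit of this assay and not a measured number, so compound 2 is known only to sit at the limit of > 100000 nM in this assay, at which 1 of the 2 values shown sits, and its true value is not fixed.

The next compound, compound 3 `N#Cc1cn(Cc2ccccc2)c2ncnc(N)c12`, keeps the core of compound 2 and differs by phenyl in place of ethyl on a saturated chain carbon bound to an aromatic nitrogen. Compound 1 also carries a phenyl on the saturated chain carbon bound to the aromatic nitrogen, and in this assay compound 1 gives 75000 nM. Going by the values given here, with only one measured comparison available, the step from compound 2 to compound 3 is expected to be small, within the scatter or a modest gain in potency at most. Compound 3 is therefore estimated at 80000 nM, with a range from 25000 nM to 300000 nM. The expected step is an at least 1.2-fold lower number from compound 2 to compound 3 (0.09 log units; that floor lies within the scatter), and a result that is again only a limit would not be surprising.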

Compound 3, half-maximal inhibitory concentration: > 100000 nM
Compound 3 was reported as a limit; the forecaster's own chance of this, stated with the estimate: 45%; at least 1.2-fold (0.09 log units) between middle value and limit.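

In this assay, putting cyano in place of carbamoyl on an aromatic carbon gives an at least 1.3-fold higher number from compound 1 to compound 3 (0.12 log units; that floor lies within the scatter), a floor that does not separate the two groups beyond the usual scatter. The step with phenyl in place of ethyl on a saturated chain carbon bound to an aromatic nitrogen cannot be read, as both of its ends are limits and not numbers. What is new is that the cyano compounds stay at the limit with either end on that chain: the limit of > 100000 nM in this assay, at which 2 of the 3 values shown sit.

From the compounds shown here alone, the true values of compound 2 and compound 3 remain unknown, and so does any real difference between cyano and carbamoyl. Going by these compounds, whether a carboxylic acid on that aromatic carbon, or a longer chain on the aromatic nitrogen, would give a number clear of the limit stays open.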